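This account rests on a few compounds, and the source may have more. Where it says the series, first, only, none or still open, it means among the compounds named here.

In a functional assay on HT-29 cells (Homo sapiens) for inhibition, read by MTT assay, with a stated time of 72 h (on this read-out lower numbers stand for stronger inhibition and higher numbers for weaker inhibition), three compounds have values so far:

compound 1 (`COc1cccc(/C=C/C(=O)Nc2cc(OC)c(OC)c(OC)c2)c1`) gives 44100 nM
compound 2 (`C=C(Br)C(=O)Nc1cccc(/C=C/C(=O)Nc2ccccc2)c1`) gives 16600 nM
compound 3 (`C=C(Br)C(=O)Nc1cccc(/C=C/C(=O)Nc2cccc3ccccc23)c1`) gives 6500 nM

Compound 2 holds the middle place among these three numbers. Compound 3 has a lower number (6500 nM) and compound 1 a higher one (44100 nM), and both gaps from compound 2 lie beyond the usual scatter of repeated measurements.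

Compound 4 (`C=C(Br)C(=O)Nc1cccc(/C=C/C(=O)Nc2cccc(F)c2)c1`) has not been measured yet. It is compound 2 with one change (fluoro in place of hydrogen on an aromatic carbon): fluoro in place of hydrogen on an aromatic carbon, so that phenyl becomes 3-fluorophenyl.

Within the data shown here, no two measured compounds differ in only one place, so the data give no direct guide to the size of this change. The change is a small one, and a small step toward a lower number is expected in this assay, quite possibly none beyond the scatter. Compound 3 (6500 nM) shows the lowest number seen so far, and compound 4 is not expected to go far past it. The estimate amounts to an expected change of a 1.4-fold lower number from compound 2 to compound 4 (0.14 log units; within the scatter) in this read-out. For compound 4 the estimated value is 12000 nM with a range from 5000 nM to 30000 nM expected.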

Compound 4, half-maximal inhibitory concentration: 4600 nM
Compound 4: the middle estimate sits 2.6-fold (0.42 log units) above what was measured; the whole stated range lies above it.
By their numbers in this assay, from the lowest: compounds 4 and 3 (each within the scatter of the next); then compound 2; then compound 1.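

In this assay, putting fluoro in place of hydrogen, which turns phenyl into 3-fluorophenyl, gives a 3.6-fold lower number from compound 2 to compound 4 (0.56 log units; beyond the scatter). Among these compounds, this is the first pair here that differs in one place only, and it shows that this position responds to the addition of a single heavy atom, with a shift larger than repeated measurements alone would produce. No measurement shown gives a reason for this step.

A single pair cannot show whether the stronger inhibition belongs to fluoro in particular or would also come with other groups at this place, such as chloro, methyl, methoxy or an amine. It also leaves open whether fluoro on another carbon of the same ring, or the same change made on the core of compound 3, would give a step of similar size.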